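Adding dimethylamino to the thiazole methyl of compound 1

The compounds below may be only part of what the source reports. "The series", "measured", "known", "first", "only" and "open" are said of these compounds alone.

This account follows compound 1, whose structure is `Cc1csc(NC(=O)c2cc(C(C)(C)C)nn2Cc2ccccc2)n1`, toward an untested relative. In a physicochemical assay for lipophilicity, read by HPLC, at pH 3.0 (a higher number here means a more lipophilic compound, a lower number a more polar compound), compound 1 gives 4.7, the highest of the three numbers recorded. The nearest of the others is compound 3, `NCc1csc(NC(=O)c2ccccc2)n1`, which in this assay gives 0.7, a gap that lies beyond the scatter. Furthest away stands compound 2, `NCc1csc(NC(=O)c2ccon2)n1`, which in this assay gives 0, again a gap beyond the scatter. Among the compounds with values here, none of these three pairs differs in only one place, so the numbers show only that compound 1 stands well apart from the two others.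

The untested compound is compound 4, `CN(C)Cc1csc(NC(=O)c2cc(C(C)(C)C)nn2Cc2ccccc2)n1`. It differs from compound 1 by dimethylamino in place of hydrogen on a saturated chain carbon bound to an aromatic carbon. Within the data shown here, no single-place step among the measured compounds shows what such a change does in this assay. Still, compound 2 and compound 3, the two measured compounds that carry an aminomethyl on the shared core, both give low numbers, so a fall beyond the scatter is expected for the step of a number 2.70 log units lower from compound 1 to compound 4 (beyond the scatter). Compound 4 is therefore estimated at 2 in this assay, within a range from 1 to 3.2.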

Compound 4, distribution coefficient: 2.6
The estimate for compound 4 lay 0.60 log units below the measured number; low and high end bracket the measured number.
By their numbers in this assay, from the lowest: compound 2; then compound 3; then compound 4; then compound 1.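

In this assay the change now has its first single-place reading: dimethylamino in place of hydrogen on a saturated chain carbon bound to an aromatic carbon gives a number 2.10 log units lower from compound 1 to compound 4 (beyond the scatter) as a large step. Until now the numbers could only set compound 1 apart from compounds that differ from it in several places, whereas here the rest of the structure stays the same and the whole step belongs to this one difference. The position, the methyl of 4-methyl-1,3-thiazol-2-yl, is thus shown to be one where a substitution moves the number well beyond the scatter, and compound 4 gives 2.6 with everything else in compound 1 kept in place. Nothing measured here accounts for the size of this fall.

On these data alone, whether an aminomethyl, a morpholine ring or a carboxylic acid at the same place would bring a step of similar size stays open, as does the effect of a longer chain carrying the dimethylamino. Within the data shown here, only this one pair speaks to the position, so it is also open whether the same change on another core would give a comparable step.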